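This account rests on a few compounds, and the source may have more. Where it says the series, first, only, none or still open, it means among the compounds named here.

In a functional assay on HeLa cells (Homo sapiens) for cytotoxicity, read by MTT assay (on this read-out higher numbers stand for weaker inhibition and lower numbers for stronger inhibition), compound 1 `COC(C)CO[C@H](CC=C(C)C)C1=CC(=O)c2c(O)ccc(O)c2C1=O` gives 53400 nM, compound 2 `CC(C)=CC[C@@H](OC(=O)CC(C)(O)C(C)C)C1=CC(=O)c2c(O)ccc(O)c2C1=O` gives 27700 nM and compound 3 `CC(C)=CC[C@@H](OC(=O)C1CCCO1)C1=CC(=O)c2c(O)ccc(O)c2C1=O` gives 17000 nM. Compound 3 stands at the low end of these numbers, but only its gap to compound 1 lies beyond the scatter. Its gap to compound 2 does not: a 1.6-fold lower number from compound 2 to compound 3 (0.21 log units; within the scatter).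

Compound 4 `CCC(CO[C@H](CC=C(C)C)C1=CC(=O)c2c(O)ccc(O)c2C1=O)OC` has not yet been measured. The change is 2-methoxybutyl in place of (oxolan-2-yl)carbonyl on an oxygen on a saturated carbon. The most relevant measured step is a 3.1-fold lower number from compound 1 to compound 3 (0.50 log units; beyond the scatter), which installs the same (oxolan-2-yl)carbonyl in place of 2-methoxypropyl. The change to compound 4 removes that group again, so a modest rise of similar size is expected in this assay. The other change at this oxygen, a 1.9-fold lower number from compound 1 to compound 2 (0.29 log units; within the scatter), stays within the scatter and adds little. The expected shift is an estimated 2.6-fold higher number from compound 3 to compound 4 (0.42 log units; beyond the scatter). Compound 4 is estimated at 45000 nM, with an expected range from 20000 nM to 90000 nM.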

Compound 4, half-maximal inhibitory concentration: 63500 nM
Compound 4: middle estimate off by 1.4-fold (0.15 log units), on the low side, within the range that was stated.
By their numbers in this assay, from the lowest: compounds 3, 2, 1 and 4 (each within the scatter of the next, the first and the last beyond it).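

In this assay, the step of a 2.3-fold higher number from compound 2 to compound 4 (0.36 log units; beyond the scatter) now separates (2-hydroxy-2,3-dimethylbutyl)carbonyl from a plain ether chain beyond the scatter, which the comparison with compound 1 could not do. The step of a 3.7-fold higher number from compound 3 to compound 4 (0.57 log units; beyond the scatter) confirms the same kind of gap for (oxolan-2-yl)carbonyl at this oxygen, while the added methyl on the chain, a 1.2-fold higher number from compound 1 to compound 4 (0.08 log units; within the scatter) and so within the scatter, has no readable effect on the number. No measurement at hand offers an explanation for these steps.

The compounds shown cannot tell whether the carbonyl or the rest of each group accounts for the gaps, and an oxolan-2-ylmethyl group, which would keep the ring and lose the carbonyl, could separate the two. From the compounds shown here alone, how an amine or a carboxylic acid at the end of the chain would read at this oxygen also remains open.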